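Benzyl in place of 2-methoxybenzyl: compound 3 to compound 4

A few compounds are considered here, and "the series" means these few. Any claim that something is new, unique, unknown or untested is made for them only; others in the source may bear on it.

Measured so far in a functional assay on P388 cells (Mus musculus) for cytotoxicity (on this read-out lower numbers stand for stronger inhibition and higher numbers for weaker inhibition), as follows

- compound 1 `COc1cccc(Cc2cn(C3CC3)c3c(F)c(-c4cc(C)nc(C)c4)c(F)cc3c2=O)c1` gives 20000 nM
- compound 2 `Cc1cc(-c2c(F)cc3c(=O)c(Cc4ccccc4O)cn(C4CC4)c3c2F)cc(C)n1` gives 670 nM
- compound 3 `COc1ccccc1Cc1cn(C2CC2)c2c(F)c(-c3cc(C)nc(C)c3)c(F)cc2c1=O` gives 37000 nM

Compound 3 belongs to the high end of these numbers. Its link to the nearest neighbour, a 1.9-fold higher number from compound 1 to compound 3 (0.27 log units; within the scatter), stays within the scatter, while its link to the hydroxy analogue, a 55-fold higher number from compound 2 to compound 3 (1.74 log units; beyond the scatter), is large.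

The next compound is compound 4 `Cc1cc(-c2c(F)cc3c(=O)c(Cc4ccccc4)cn(C4CC4)c3c2F)cc(C)n1`, which carries hydrogen in place of methoxy on an aromatic carbon, ortho to a large group (hydrogen in place of methoxy on an aromatic carbon). The same difference reads as 2-methoxybenzyl to benzyl.

Among the measured compounds shown here, no measured step removes the substituent outright, so the evidence is indirect. Moving the methoxy group gave a 1.9-fold higher number from compound 1 to compound 3 (0.27 log units; within the scatter), a change within the scatter. The large step of a 30-fold lower number from compound 1 to compound 2 (1.47 log units; beyond the scatter) introduced a hydroxy group, and compound 4 has none. The low value of compound 2 (670 nM) is therefore not expected to carry over in full. A modest move towards a lower number is expected, though the direction is uncertain, and the expected step is a 3.1-fold lower number from compound 3 to compound 4 (0.49 log units; beyond the scatter) in this assay. Compound 4 is estimated at 12000 nM, with an expected range from 2500 nM to 40000 nM.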

Compound 4, half-maximal inhibitory concentration: 7300 nM
Compound 4: middle estimate off by 1.6-fold (0.22 log units), on the high side; low and high end bracket the measured number.
By their numbers in this assay, from the lowest: compound 2; then compound 4; then compounds 1 and 3 (each within the scatter of the next).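

With compound 4, the unsubstituted benzyl group gives a hydrogen reference for this ring in this assay, so the methoxy and hydroxy groups can now be read against it rather than only against each other. Hydrogen in place of methoxy lowers the number in both methoxy compounds (a 5.1-fold lower number from compound 3 to compound 4 (0.70 log units; beyond the scatter); a 2.7-fold lower number from compound 1 to compound 4 (0.44 log units; beyond the scatter)), while hydrogen in place of hydroxy raises it (an 11-fold higher number from compound 2 to compound 4 (1.04 log units; beyond the scatter)), which places the benzyl compound between the hydroxy compound and the two methoxy compounds and shows that a substituent on this ring can move the number either way from hydrogen. Nothing measured alongside these numbers bears on why the groups differ.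

It remains open whether a hydroxy group keeps the low number when it sits where the methoxy group stands in compound 1, since the only hydroxy compound shown is the 2-hydroxyphenyl one. An amine or a carboxylic acid on this ring could show whether the low number is specific to hydroxy or also follows other groups in that place.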